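Swapping the Sulfanyl Linker for a Carbon Chain

A few compounds are considered here, and "the series" means these few. Any claim that something is new, unique, unknown or untested is made for them only; others in the source may bear on it.

Compound 1, `CCOC(=O)c1c(CSc2nncn2C)nc2cc(OC)c(OC)cc2c1-c1ccc(OC)c(OC)c1`, gives 66% in a functional assay on the whole organism for inhibition, with Rattus norvegicus as the target, at a dose of 50 mg/kg by the oral route; on this read-out higher numbers stand for more inhibition at the one dose given (going by the name of the read-out) and lower numbers for less inhibition.
Compound 2, `CCOC(=O)c1c(CSc2nccn2C)nc2cc(OC)c(OC)cc2c1-c1ccccc1`, gives 31% in this assay.
Compound 3, `CCOC(=O)c1c(CSc2nccn2C)nc2ccccc2c1-c1ccc(OC)c(OC)c1`, gives 33% in this assay.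

Among the three measured compounds, compound 1 has the highest number in this assay. Its nearest neighbour is compound 3, whose value lies well beyond the scatter below it, and compound 2 sits further still. Compounds 2 and 3 differ from compound 1 in more than one place, so no single step can be read from either of them.

Compound 4, `CCOC(=O)c1c(CCc2nccn2C)nc2cc(OC)c(OC)cc2c1-c1ccc(OC)c(OC)c1`, has not been measured in this assay. It differs from compound 1 by (1-methyl-1H-imidazol-2-yl)methyl in place of (4-methyl-4H-1,2,4-triazol-3-yl)sulfanyl on a saturated chain carbon bound to an aromatic carbon. For the measured compounds named here, both the ring and the atom joining it to the chain change at once, and no measured pair shows this change on its own. Compound 4 is expected to fall below compound 1, a step of a number 21 percentage points lower from compound 1 to compound 4 (beyond the scatter), since the two other measured compounds with a sulfanyl-linked ring already stand far lower. The estimate for compound 4 is 45%, with a range from 20% to 70%.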

Compound 4, a percentage reported as inhibition, in the whole organism at one dose (the size of the read-out at that dose, not a potency): 75%
Beside the measured number, compound 4's estimate is 30 percentage points below it; the whole stated range lies below it.
By their numbers in this assay, from the lowest: compounds 2 and 3 (each within the scatter of the next); then compounds 1 and 4 (each within the scatter of the next).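

In this assay, putting (1-methyl-1H-imidazol-2-yl)methyl in place of (4-methyl-4H-1,2,4-triazol-3-yl)sulfanyl gives a number 9 percentage points higher from compound 1 to compound 4 (within the scatter). This is the only single step shown at this position, and it shows that the sulfur atom and the triazole ring can both leave without a change in inhibition beyond the scatter at this one dose. No measurement shown here offers an explanation for this result.

Since the ring and the joining atom change together, the share of each in the step stays unresolved. Also open, from the compounds shown here alone, is how this position would respond to a longer chain, such as 3-(1-methyl-1H-imidazol-2-yl)propyl, or to an amine, such as dimethylamino, in place of the ring.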